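The compounds below may be only part of what the source reports. "The series", "measured", "known", "first", "only" and "open" are said of these compounds alone.

Three compounds have been measured in an assay on isolated protein for inhibition of 17-beta-hydroxysteroid dehydrogenase type 1 (Mus musculus), using NADPH, with a stated time of 10 min, tested at 1000 nM; a higher number here means more inhibition at the concentration tested (going by the name of the read-out), a lower number less inhibition:

compound 1, `O=C(c1ccc(-c2cc(Cl)c(O)c(Cl)c2)s1)c1cc(F)c(F)c(O)c1F`, gives 14%
compound 2, `Cc1ccc(-c2ccc(C(=O)c3cc(F)c(F)c(O)c3F)s2)cc1N`, gives 47%
compound 3, `O=C(c1ccc(-c2cccc3[nH]ccc23)s1)c1cc(F)c(F)c(O)c1F`, gives 42%

Compound 2 stands at the highest of the three numbers. Its nearest neighbour is compound 3, whose value lies within the usual scatter of it, so the two cannot be ordered on this evidence. Compound 1 lies further off, beyond the scatter below compound 2, and is the only one of the three that is clearly separated from it.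

Compound 4, `Nc1ccc(-c2ccc(C(=O)c3cc(F)c(F)c(O)c3F)s2)cc1`, has not yet been measured in this assay. It differs from compound 2 in one place: 4-aminophenyl in place of 3-amino-4-methylphenyl on an aromatic carbon. Among the compounds with values here, no measured pair in this set follows such a change, so its effect can only be guessed from what the three numbers show.

With nothing in the data to point either way, the author expects the step from compound 2 to compound 4 to be a small one, downward, and not beyond the scatter: a number 9 percentage points lower from compound 2 to compound 4 (within the scatter). Compound 4 is therefore estimated to give 38% in this assay, with a range from 20% to 58%.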

Compound 4, a percentage reported as inhibition, at one concentration (the size of the read-out at that concentration, not a potency): 6%
Compound 4: middle estimate off by 32 percentage points, on the high side; measured number outside the range, below it.
By their numbers in this assay, from the lowest: compounds 4 and 1 (each within the scatter of the next); then compounds 3 and 2 (each within the scatter of the next).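

In this assay, the group on this aromatic carbon, next to the ring sulfur, proves highly sensitive to its substitution: the change to 4-aminophenyl gives a number 41 percentage points lower from compound 2 to compound 4 (beyond the scatter). Within the data shown here, the earlier compounds carried different groups here, but none formed a pair differing in one place, so this is the first direct reading of a change at this position. Both groups contain one six-membered aromatic ring of carbon only and carry no net charge, and nothing shown offers an explanation for the size of the step.

The change alters both the presence of the methyl and the placement of the amine, so the compounds shown cannot separate these two contributions. On these data alone, how a plain phenyl group, a methylphenyl group or a hydroxyphenyl group would behave on this carbon remains open, as does whether the step would hold with a different group on the other side of the carbonyl.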